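Swapping fluoro for hydroxy on a citrate-like inhibitor

The source may report more compounds than this note shows. Statements on the series, on what has been measured and on what is new or still open speak of the compounds shown alone.

Among the compounds with values here, compound 2 `O=C(O)CC(O)(CSCCCCCCc1ccc(F)cc1)C(=O)O` is one of two compounds so far tested in an assay on isolated protein for inhibition of ATP-citrate synthase (Rattus norvegicus) (a lower number here means a stronger inhibitor, a higher number a weaker inhibitor), where compound 2 gives 120000 nM. Compound 1 `O=C(O)CC(O)(CSCCCCCc1ccccc1)C(=O)O` is the other; in this assay compound 1 gives 490000 nM. Among these two numbers compound 2 has the lower one, and the only measured step, a 4.1-fold lower number from compound 1 to compound 2 (0.61 log units; beyond the scatter), leads to it.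

Compound 3 `O=C(O)CC(O)(CSCCCCCCc1ccc(O)cc1)C(=O)O` has not yet been measured in this assay. It differs from compound 2 in one place: hydroxy in place of fluoro on an aromatic carbon. Within the data shown here, only one measured step exists, the step from compound 1 to compound 2, and it alters the chain and adds a substituent at once rather than exchanging one substituent for another on the ring, so it bears on this change only loosely. Among the measured compounds shown here, no measured pair shows a fluoro exchanged for a hydroxy, so the step expected in this assay from compound 2 to compound 3 is small, a 1.3-fold higher number from compound 2 to compound 3 (0.10 log units; within the scatter), in no certain direction. Compound 3 is therefore estimated at 150000 nM, with a range from 50000 nM to 450000 nM.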

Compound 3, inhibition constant: 420000 nM
Beside the measured number, compound 3's estimate is 2.8-fold (0.45 log units) below it, and the stated range covers the measured number.
By their numbers in this assay, from the lowest: compound 2; then compounds 3 and 1 (each within the scatter of the next).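

In this assay, hydroxy in place of fluoro on an aromatic carbon, para to a large group, gives a 3.5-fold higher number from compound 2 to compound 3 (0.54 log units; beyond the scatter), so this ring position responds to which single atom it carries, something the earlier pair could not show. The second new step, a 1.2-fold lower number from compound 1 to compound 3 (0.07 log units; within the scatter), sets beside the earlier 4.1-fold lower number from compound 1 to compound 2 (0.61 log units; beyond the scatter) and shows that the change from phenyl to a 4-substituted benzyl does not by itself bring a lower number: among these compounds that happens with 4-fluorobenzyl and not with 4-hydroxybenzyl. Nothing available on these compounds gives a reason for the gap between fluoro and hydroxy at this position.

From the compounds shown here alone, whether another group at the same ring position, such as chloro, methoxy or an amine, would fall nearer compound 2 or nearer compound 3 remains open. Also open, going by these compounds, is whether the fluoro keeps its advantage over hydroxy on a longer chain, since the comparison here rests on a single chain and a single ring position.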